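Swapping the aryl group on the alkyne of compound 1

The source may report more compounds than this note shows. Statements on the series, on what has been measured and on what is new or still open speak of the compounds shown alone.

In a functional assay on BaF3 cells (Mus musculus) for antiproliferative activity (a lower number here means that less compound is needed, a higher number that more compound is needed for the effect), the measured compounds are these

Compound 1 `CCN1CCN(Cc2ccc(NC(=O)c3ccc(C)c(C#Cc4ccc(NC(=O)C5CC5)nc4)c3)cc2C(F)(F)F)CC1` gives 1800 nM
Compound 2 `CCN1CCN(Cc2ccc(NC(=O)c3ccc(C)c(C#Cc4cnc5[nH]c(C)cc5c4)c3)cc2C(F)(F)F)CC1` gives 1000 nM

For the measured compounds named here, compound 1 and compound 2 lie within the scatter of each other, so compound 1 stands level with the only other compound measured. Compound 3 (`CCN1CCN(Cc2ccc(NC(=O)c3ccc(C)c(C#Cc4cnc5nccnc5c4)c3)cc2C(F)(F)F)CC1`) has not been measured yet. It differs from compound 1 as follows: a group of 10 heavy atoms (7 carbon, 3 nitrogen; one six-membered aromatic ring with 1 hetero atom, one six-membered aromatic ring with 2 hetero atoms) in place of a group of 12 heavy atoms (9 carbon, 2 nitrogen, 1 oxygen; one three-membered non-aromatic ring of carbon only, one six-membered aromatic ring with 1 hetero atom), on a triple-bonded carbon and the group that leaves is the 6-((cyclopropylcarbonyl)amino)pyridin-3-yl.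

Going by the values given here, the only measured step that bears on this change is a 1.8-fold lower number from compound 1 to compound 2 (0.26 log units; within the scatter) and it removes the same group from the same triple-bonded carbon. Among the compounds with values here, the group entering in compound 2 is not the one entering in compound 3, however, since it has a five-membered aromatic ring, so this single step is only a loose guide. With nothing else to go on, no change beyond the scatter is expected in this assay in either direction. The estimate amounts to a 1.5-fold lower number from compound 1 to compound 3 (0.18 log units; within the scatter) and this expected step remains small. Compound 3 is estimated at 1200 nM with a range of 400 nM to 3500 nM expected for it.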

Compound 3, half-maximal effective concentration: 3320 nM
The estimate for compound 3 lay 2.8-fold (0.44 log units) below the measured number; low and high end bracket the measured number.
By their numbers in this assay, from the lowest: compounds 2, 1 and 3 (each within the scatter of the next, the first and the last beyond it).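

In this assay, the new result shows that this triple-bonded carbon can tell apart two groups of the same heavy-atom count: a 3.3-fold higher number from compound 2 to compound 3 (0.52 log units; beyond the scatter) is a modest step beyond the scatter, whereas the earlier comparison showed only a step within it. The replacement of the 6-((cyclopropylcarbonyl)amino)pyridin-3-yl group by a second fused aromatic group, a 1.8-fold higher number from compound 1 to compound 3 (0.27 log units; within the scatter), also stays within the scatter, so neither fused group stands clearly apart from the group in compound 1, although the two differ from each other. Nothing measured on these compounds explains the gap between compound 2 and compound 3.

The compounds shown leave open whether that gap follows from the five-membered ring of compound 2 or from the different hetero atoms in the group of compound 3, as the two groups differ in both at once. They also leave open how a plain phenyl group, or a pyridin-3-yl group carrying a free amine in place of the cyclopropylcarbonyl amide, would compare on this triple-bonded carbon.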